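Fluoro in place of bromo on compound 2

The compounds below may be only part of what the source reports. "The series", "measured", "known", "first", "only" and "open" are said of these compounds alone.

Measured in a functional assay on LOX IMVI cells (Homo sapiens) for cytotoxicity, read by MTT assay, with a stated time of 24 h; a lower number here means a stronger inhibitor, a higher number a weaker inhibitor
compound 1 `COc1cc(-c2nc(-c3ccccc3)[nH]c2-c2ccnc(NCCCNS(=O)(=O)c3ccc(F)cc3)n2)ccc1F` gives 3960 nM
compound 2 `COc1cc(-c2nc(-c3ccccc3)[nH]c2-c2ccnc(NCCCNS(=O)(=O)c3ccc(Br)cc3)n2)ccc1Cl` gives 23700 nM

Compound 2 stands highest of these two numbers, and its gap to compound 1 lies beyond the scatter. Compound 3 `COc1cc(-c2nc(-c3ccccc3)[nH]c2-c2ccnc(NCCCNS(=O)(=O)c3ccc(F)cc3)n2)ccc1Cl` is compound 2 with one change, fluoro in place of bromo on an aromatic carbon para to a large group. Within the data shown here, no measured pair differs in one place alone, so the size of this step remains uncertain. Compound 3 does share the 4-fluorophenyl group with compound 1, which reads 3960 nM in this assay, so a downward step beyond the scatter is expected. The expected change is a 3.0-fold lower number from compound 2 to compound 3 (0.47 log units; beyond the scatter) in this estimate. For compound 3 the estimated value is 8000 nM, within an expected range from 3000 nM to 20000 nM overall.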

Compound 3, half-maximal inhibitory concentration: 4530 nM
Estimate against measurement, compound 3: 1.8-fold (0.25 log units) above, and the stated range covers the measured number.
By their numbers in this assay, from the lowest: compounds 1 and 3 (each within the scatter of the next); then compound 2.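

In this assay the change from 4-bromophenyl to 4-fluorophenyl can now be read on its own, as a 5.2-fold lower number from compound 2 to compound 3 (0.72 log units; beyond the scatter), so the group at this place on the sulfonyl side alters the number. The second exchange, chloro in place of fluoro on an aromatic carbon at the other site, gives a 1.1-fold higher number from compound 1 to compound 3 (0.06 log units; within the scatter), and so shows no readable change in this pair. Nothing measured here gives a reason for either step.

The compounds shown leave open how a chloro, a methyl or a nitrile would read in place of the fluoro on the 4-fluorophenyl group, and so whether bromo alone stands apart. As far as these compounds go, it also remains open whether the bromo to fluoro step keeps its size when the other site carries fluoro instead of chloro.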